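Removing a hydroxy from compound 2: what to expect

A few compounds are considered here, and "the series" means these few. Any claim that something is new, unique, unknown or untested is made for them only; others in the source may bear on it.

Measured compounds:
compound 1, `CCN(Cc1ccc(Br)cc1)c1ccc(C(=O)N2CCc3ccc(OS(N)(=O)=O)cc3C2)cc1`, 95.9%
compound 2, `NS(=O)(=O)Oc1ccc2c(c1)CN(C(=O)c1ccc(N(CCCO)Cc3ccccc3)cc1)CC2`, 64.3%

Of the compounds shown here, two share a core and have been tested in an assay on HEK293 cells for inhibition of Steryl-sulfatase (Homo sapiens), tested at 1 uM; a higher number here means a stronger effect of the compound at the concentration tested, a lower number a weaker effect. Compound 1 gives 95.9%, while compound 2 gives 64.3%, the lower of the two numbers, a gap that lies beyond the usual scatter. The two compounds differ in more than one place, so these numbers alone do not tell which part of the difference matters.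

Compound 3, `CCCN(Cc1ccccc1)c1ccc(C(=O)N2CCc3ccc(OS(N)(=O)=O)cc3C2)cc1`, has not been measured. It differs from compound 2 in a single way: hydrogen in place of hydroxy on a saturated chain carbon, three bonds along the chain from a nitrogen on an aromatic ring. Among the measured compounds shown here, no measured pair shows this exact change, so the direction and size of its effect are open. For the measured compounds named here, the only hint is that compound 1, which also lacks a hydroxy, gave 95.9%. On that basis a moderate rise in this assay is expected, of the order of a number 15.7 percentage points higher from compound 2 to compound 3 (beyond the scatter), though a step within the scatter cannot be ruled out. Compound 3 is therefore estimated at 80%, with a likely range from 60% to 95%.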

Compound 3, a percentage reported as inhibition, at one concentration (the size of the read-out at that concentration, not a potency): 94.3%
Estimate against measurement, compound 3: 14.3 percentage points below; low and high end bracket the measured number.
By their numbers in this assay, from the lowest: compound 2; then compounds 3 and 1 (each within the scatter of the next).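

Hydrogen in place of hydroxy, which turns 3-hydroxypropyl into propyl, now has a direct reading in this assay: a number 30 percentage points higher from compound 2 to compound 3 (beyond the scatter), so the single oxygen on this chain carbon is enough on its own to separate the two numbers. Compound 1 no longer stands alone at the high end, as benzyl(propyl)amino in place of (4-bromobenzyl)(ethyl)amino on the aromatic carbon gives a number 1.6 percentage points lower from compound 1 to compound 3 (within the scatter), which means that these two compounds cannot be told apart at this one concentration. The pair shows how much the number moves with this change but not the reason for it, and nothing measured here offers an explanation.

Going by these compounds, it remains open whether the drop belongs to the hydroxy itself or would follow other groups on the same chain carbon, and a methoxy, an amine or a carboxylic acid there would help to separate those readings, as would a longer chain ending in hydroxy. Because the read-out gives the size of the effect at a single concentration rather than a potency, any difference in potency between compound 1 and compound 3 also remains unresolved.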